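A few compounds are considered here, and "the series" means these few. Any claim that something is new, unique, unknown or untested is made for them only; others in the source may bear on it.

In a functional assay on HeLa cells (Homo sapiens) for inhibition, read by CCK-8 assay, with a stated time of 48 h (a lower number here means a stronger inhibitor, a higher number a weaker inhibitor), compound 1 `COc1cc(-c2cc3nccc(-c4cc(OC)c(OC)c(OC)c4)n3n2)cc(OC)c1OC` gives > 10000 nM as its reading, which is a limit of the assay and not a number. Going by the values given here, compound 2 `COc1cc(-c2ccnc3cc(-c4ccc(C)c(C)c4)nn23)cc(OC)c1OC` gives 241 nM in this assay and so holds the only true number in this small set, which leaves it with no measured value to be ranked against.

Compound 3 `COc1cc(-c2ccnc3cc(-c4ccc(C(F)(F)F)cc4)nn23)cc(OC)c1OC` has not yet been measured. It matches compound 2 except for one group on an aromatic carbon of a five-membered aromatic ring with 2 nitrogen, where 4-(trifluoromethyl)phenyl comes in place of 3,4-dimethylphenyl (4-(trifluoromethyl)phenyl in place of 3,4-dimethylphenyl on an aromatic carbon). Among the compounds with values here, no two measured compounds differ in just one place, so the data give no direct guide to what this swap does. One substituted phenyl replacing another is expected to keep compound 3 clear of the limit, with a modest weakening as the best guess. The estimated change is a 2.5-fold higher number from compound 2 to compound 3 (0.40 log units; beyond the scatter) as a small loss, only a little beyond the usual scatter. For compound 3 the estimate is 600 nM in this assay, with a deliberately wide expected range from 120 nM to 3000 nM on this thin evidence.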

Compound 3, half-maximal inhibitory concentration: 1840 nM
The estimate for compound 3 lay 3.1-fold (0.49 log units) below the measured number; the measured number falls inside the stated range.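

Swapping 3,4-dimethylphenyl for 4-(trifluoromethyl)phenyl on this aromatic carbon of the five-membered ring gives, in this assay, a 7.6-fold higher number from compound 2 to compound 3 (0.88 log units; beyond the scatter), so this position does respond to which substituted phenyl it carries. Going by these compounds alone, this is the first single change in the set that can be read as a step, and it shows a real but modest cost, with compound 3 still giving a true number and not a limit of the assay. Nothing measured here accounts for the loss.

One pair cannot separate the departure of the two methyl groups from the arrival of the trifluoromethyl group, which leaves open whether an unsubstituted phenyl, a 4-methylphenyl or a 4-chlorophenyl would read closer to compound 2 or to compound 3. As far as these compounds go, it also remains open how this position would respond to something other than a substituted phenyl, such as a morpholine or a carboxylic acid, and whether the step seen here would hold on a different part of the shared core.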